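Moving from 2-chlorobenzyl to 3-bromobenzyl

This account rests on a few compounds, and the source may have more. Where it says the series, first, only, none or still open, it means among the compounds named here.

Values in a functional assay on A2780 cells (Homo sapiens) for antiproliferative activity, read by resazurin assay, with a stated time of 72 h; a higher number here means a weaker inhibitor, a lower number a stronger inhibitor:
Compound 1 `NC(=O)c1cc2c(Cc3ccccc3)n[nH]c2cc1O`: "not determined" (no result reported)
Compound 2 `CN(C(=O)c1cc2c(Cc3ccccc3)n[nH]c2cc1O)c1ccco1`: 2500 nM
Compound 3 `CN(Cc1ccccc1Cl)C(=O)c1cc2c(Cc3ccccc3)n[nH]c2cc1O`: 1100 nM

Compound 3 has the lower of the two numbers available, and compound 1 offers no number for comparison. Compound 4 `CN(Cc1cccc(Br)c1)C(=O)c1cc2c(Cc3ccccc3)n[nH]c2cc1O` differs from it in one place: 3-bromophenyl in place of 2-chlorophenyl on a saturated chain carbon bound to an amide-type nitrogen. In words, 3-bromophenyl stands in place of 2-chlorophenyl on a saturated chain carbon bound to an amide-type nitrogen. Among the compounds with values here, the only measured step with a bearing on this is a 2.3-fold lower number from compound 2 to compound 3 (0.36 log units; beyond the scatter), which replaced furan-2-yl with 2-chlorobenzyl. Within the data shown here, no measured pair shows a change like the one in compound 4, so no step beyond the scatter is expected in this assay, in either direction. The expected change is a 1.1-fold lower number from compound 3 to compound 4 (0.04 log units; within the scatter). For compound 4 the estimated value is 1000 nM, with an expected range of 400 nM to 2500 nM.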

Compound 4, half-maximal inhibitory concentration: 7100 nM
Compound 4: middle estimate off by 7.1-fold (0.85 log units), on the low side; the whole stated range lies below it.
By their numbers in this assay, from the lowest: compound 3; then compound 2; then compound 4.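

In this assay, this place on the saturated chain carbon bound to an amide-type nitrogen proves sensitive to the aryl group it carries: 3-bromophenyl in place of 2-chlorophenyl gives a 6.5-fold higher number from compound 3 to compound 4 (0.81 log units; beyond the scatter). The same change reverses the gain over the furan-2-yl amide, with a 2.8-fold higher number from compound 2 to compound 4 (0.45 log units; beyond the scatter), so a halogenated benzyl group on this nitrogen does not by itself give the lower number. Nothing available explains this difference. The halogen and its ring position changed together, and 3-chlorobenzyl or 2-bromobenzyl would be needed to separate them.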